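From methoxy to methyl on the shared core

A few compounds are considered here, and "the series" means these few. Any claim that something is new, unique, unknown or untested is made for them only; others in the source may bear on it.

In a functional assay on Jurkat cells (Homo sapiens) for cytotoxicity, read by MTT assay, with a stated time of 24 h (a higher number here means that more compound is needed for the effect, a lower number that less compound is needed), compound 3 (`CCOC(=O)c1cc([Se]c2ccccc2)c2cc(OC)ccc2n1`) gives 102000 nM and compound 2 (`CCOC(=O)c1cc([Se]c2ccccc2)c2cc(Cl)ccc2n1`) gives 53000 nM while compound 1 (`CCOC(=O)c1cc([Se]c2ccccc2)c2cc(Br)ccc2n1`) gives 20800 nM as the lowest number. Compound 3 therefore sits level with compound 2 (a 1.9-fold higher number from compound 2 to compound 3 (0.28 log units; within the scatter)) and clearly apart from compound 1 (a 4.9-fold higher number from compound 1 to compound 3 (0.69 log units; beyond the scatter)).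

Compound 4 (`CCOC(=O)c1cc([Se]c2ccccc2)c2cc(C)ccc2n1`) carries methyl in place of methoxy on an aromatic carbon. Going by the values given here, no measured step makes this exact swap, but all three measured steps change the same group on the shared core. Besides the two above, there is one more (a 2.5-fold higher number from compound 1 to compound 2 (0.41 log units; beyond the scatter)). Even the largest of these is modest, so a large jump seems unlikely here. Methyl is neither of the halogens, and the data do not show where it should fall among these groups. The expected step is a 1.7-fold lower number from compound 3 to compound 4 (0.23 log units; within the scatter) and so only a small drift toward a lower number. In this assay the estimate for compound 4 is 60000 nM with 25000 nM to 130000 nM as its expected range.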

Compound 4, half-maximal effective concentration: 15300 nM
For compound 4 the middle estimate is 3.9-fold (0.59 log units) above the measured one, outside the stated range (below it).
By their numbers in this assay, from the lowest: compounds 4 and 1 (each within the scatter of the next); then compounds 2 and 3 (each within the scatter of the next).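

In this assay, methyl in place of methoxy gives a 6.7-fold lower number from compound 3 to compound 4 (0.82 log units; beyond the scatter) and methyl in place of chloro gives a 3.5-fold lower number from compound 2 to compound 4 (0.54 log units; beyond the scatter) on this aromatic carbon. Methyl in place of bromo gives a 1.4-fold lower number from compound 1 to compound 4 (0.13 log units; within the scatter) and so, on the shared core, a group that is not a halogen stands level with bromo at the low end of the numbers. The four groups therefore do not divide into halogens and the rest, since chloro stays level with methoxy while bromo stays level with methyl.

Where an amine, a carboxylic acid or a longer chain such as ethyl would fall at this position remains open. Nothing shown here offers a measured reason for the split between these two pairs of compounds.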